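Stereoisomers in the benzyl-protected series: compound 3 to compound 4

The compounds below may be only part of what the source reports. "The series", "measured", "known", "first", "only" and "open" are said of these compounds alone.

Values in a functional assay on HL-60 cells (Homo sapiens) for antiproliferative activity, read by MTT assay (a higher number here means a weaker inhibitor, a lower number a stronger inhibitor), for the measured compounds
- compound 1 `CCC[C@@H]1O[C@H](COCc2ccccc2)[C@@H](OCc2ccccc2)[C@H](OCc2ccccc2)[C@@H]1O` gives "not active" (no number reported)
- compound 2 `CC(C)C[C@H]1O[C@H](COCc2ccccc2)[C@@H](OCc2ccccc2)[C@H](OCc2ccccc2)[C@@H]1O` gives "not active" (no number reported)
- compound 3 `CC(C)C[C@H]1O[C@H](COCc2ccccc2)[C@@H](OCc2ccccc2)[C@H](OCc2ccccc2)[C@H]1O` gives 13900 nM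

Among the measured compounds shown here, compound 3 at 13900 nM holds the only number in the set, and the other two entries carry no number. Comparison with the fact that compounds 2 and 3 differ only in the configuration as drawn is instructive: compound 2 gives "not active" (no number reported) while compound 3 gives 13900 nM in the same assay, so within this pair configuration alone separates a number from none.

The next compound to be measured is compound 4 `CC(C)C[C@@H]1O[C@H](COCc2ccccc2)[C@@H](OCc2ccccc2)[C@H](OCc2ccccc2)[C@@H]1O` which keeps the atoms and bonds of compound 3 and departs from it as follows: the two compounds have the same atoms and bonds and differ only in configuration as drawn: 2 of 5 stereo elements differ; a stereocentre at a saturated ring carbon is drawn R in compound 3 and S in compound 4; a stereocentre at a saturated ring carbon is drawn S in compound 3 and R in compound 4 with no group leaving or entering.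

For the measured compounds named here, no measured step gives a size for such a change. Since compound 1 gives "not active" (no number reported) and compound 2 gives "not active" (no number reported) in this assay the expectation leans toward weaker inhibition, and a report with no number is nearly as likely as a value. The expected change is a 2.2-fold higher number from compound 3 to compound 4 (0.33 log units; beyond the scatter) in that direction, if a number is reported at all. For compound 4 the estimated half-maximal inhibitory concentration is 30000 nM with an expected range from 10000 nM to 90000 nM in this reading.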

Compound 4, half-maximal inhibitory concentration: "not active" (no number reported)
For compound 4 the study gives words and no number, so the estimate cannot be set against anything.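

In this assay, among the compounds shown here, compound 4 gives "not active" (no number reported) and compound 3 gives 13900 nM, so no step between these two stereoisomers can be read. The compounds shown leave open how large any difference among the stereoisomers compound 2, compound 3 and compound 4 is, as compound 3 alone carries a number.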